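Methoxy on the phenoxy ring: permeability notes

The source may report more compounds than this note shows. Statements on the series, on what has been measured and on what is new or still open speak of the compounds shown alone.

Compound 2 `c1ccc(Oc2ccc3c(NCCCNCc4ccco4)ccnc3c2)cc1` has been measured in an ADME assay for permeability, using PAMPA, with a stated time of 30 min, at pH 7.4 (a lower number here means that the compound crosses the layer more slowly, a higher number that the compound crosses the layer faster), where compound 2 gives 317 10^-6 cm/s. On the two numbers shown compound 2 stands alongside compound 1 `FC(F)(F)c1ccc(-c2ccc3c(NCCCNCc4ccco4)ccnc3c2)cc1`, which in this assay gives 237 10^-6 cm/s; the two values lie within the scatter of each other, and the one measured step, a 1.3-fold higher number from compound 1 to compound 2 (0.13 log units; within the scatter), is accordingly not a real difference. Compound 3 `COc1ccc(Oc2ccc3c(NCCCNCc4ccco4)ccnc3c2)cc1` has not yet been measured. Relative to compound 2 the change is methoxy in place of hydrogen on an aromatic carbon; cut one bond further out it reads phenoxy to 4-methoxyphenoxy. Among the measured compounds shown here, no measured step bears directly on this change: the single step available, a 1.3-fold higher number from compound 1 to compound 2 (0.13 log units; within the scatter), exchanges the whole aryl group rather than adding a methoxy to it, and it stayed within the scatter. Both measured values are of similar size, and nothing in the series points to a direction for a methoxy. The step of a 1.1-fold lower number from compound 2 to compound 3 (0.02 log units; within the scatter) is therefore expected to stay within the scatter. Compound 3 is estimated at 300 10^-6 cm/s, with a range from 180 10^-6 cm/s to 450 10^-6 cm/s.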

Compound 3, apparent permeability: 317 10^-6 cm/s
Estimate against measurement, compound 3: 1.1-fold (0.02 log units) below; low and high end bracket the measured number.
By their numbers in this assay, from the lowest: compounds 1, 2 and 3 (each within the scatter of the next).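

In this assay the series now has its first direct reading of methoxy in place of hydrogen at this place, on an aromatic carbon para to a large group, and it gives no change at the digits printed from compound 2 to compound 3 (within the scatter). The wider exchange of 4-(trifluoromethyl)phenyl for 4-methoxyphenoxy at the same attachment point gives a 1.3-fold higher number from compound 1 to compound 3 (0.13 log units; within the scatter), so all three aryl-bearing groups shown lie within the scatter of each other, and neither the added methoxy nor the whole-group exchange produces a step that can be read as real. No supporting data are available that bear on why these values stay together.

Whether a carboxylic acid or an amine on this ring would give a step beyond the scatter remains open, since the groups shown at this position span only trifluoromethyl-substituted phenyl, phenoxy and 4-methoxyphenoxy. Among the compounds shown here, also open is whether the same flat reading would hold for methoxy elsewhere on the phenoxy ring, or for a longer chain in place of the one shared by compounds 1, 2 and 3.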